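The compounds below may be only part of what the source reports. "The series", "measured", "known", "first", "only" and "open" are said of these compounds alone.

In a functional assay on the whole organism (strain Wistar) for inhibition, with Rattus norvegicus as the target, read by paw edema, with stated times of 30 min and 3 h, at a dose of 20 mg/kg (a higher number here means more inhibition at the dose given (going by the name of the read-out), a lower number less inhibition), compound 3 `CCOC(=O)C1=C(C)NC(C)=C(C(=O)OCC)C1c1ccc(OCC(=O)NNC(=O)c2ccccc2)cc1` gives 44.9%. Among the three measured compounds this is the second highest number: compound 1 `CCOC(=O)C1=C(C)NC(C)=C(C(=O)OCC)C1c1ccc(OCC(=O)NCc2ccccc2)cc1` gives 31.1%, and compound 2 `CCOC(=O)C1=C(C)NC(C)=C(C(=O)OCC)C1c1ccc(OCC(=O)Nc2ccc(C)cc2)cc1` gives 61.1%. The steps of a number 13.8 percentage points higher from compound 1 to compound 3 (beyond the scatter) and a number 16.2 percentage points lower from compound 2 to compound 3 (beyond the scatter) were both modest. Compound 4 `CCOC(=O)C1=C(C)NC(C)=C(C(=O)OCC)C1c1ccc(OCC(=O)NNC(=O)c2cccs2)cc1` differs from compound 3 in one place: thiophen-2-yl in place of phenyl on a carbonyl carbon. Every measured step, including a number 30 percentage points higher from compound 1 to compound 2 (beyond the scatter), changes the group on the amide-type nitrogen, so none bears directly on a swap on the carbonyl carbon. With no direct guide, the step of a number 0.1 percentage points higher from compound 3 to compound 4 (within the scatter) is expected to stay within the scatter. Compound 4 is therefore estimated at 45%, in a range from 30% to 60%.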

Compound 4, a percentage reported as inhibition, in the whole organism at one dose (the size of the read-out at that dose, not a potency): 61.1%
Compound 4: the middle estimate sits 16.1 percentage points below what was measured; measured number above the stated range.
By their numbers in this assay, from the lowest: compound 1; then compound 3; then compounds 2 and 4 (each within the scatter of the next).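

Changing the ring on the carbonyl carbon also moves the result in this assay, not only changing the group on the amide-type nitrogen: thiophen-2-yl in place of phenyl gives a number 16.2 percentage points higher from compound 3 to compound 4 (beyond the scatter). With this ring, the side chain shows no change at the digits printed from compound 2 to compound 4 (within the scatter) and a number 30 percentage points higher from compound 1 to compound 4 (beyond the scatter), so it matches the 4-methylphenyl amide of compound 2. No evidence here explains the effect of this ring. From the compounds shown here alone, whether furan-2-yl, pyridin-2-yl or a simple methyl on the same carbonyl carbon would give a similar number remains open.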